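Cyclopropylamino in Place of Ethoxy on the Shared Core

This account rests on a few compounds, and the source may have more. Where it says the series, first, only, none or still open, it means among the compounds named here.

In a functional assay on MOLT-4 cells (Homo sapiens) (on this read-out higher numbers stand for weaker inhibition and lower numbers for stronger inhibition), three compounds sharing one core have been measured. Compound 1 `OC[C@H]1C[C@@H](Cn2cnc3c(-c4ccc(Cl)cc4)ncnc32)c2ccccc21` carries a 4-chlorophenyl group and gives 0.63 ug/mL. Compound 2 `OC[C@H]1C[C@@H](Cn2cnc3c(O)ncnc32)c2ccccc21` carries a hydroxy group at the same aromatic carbon and gives 24 ug/mL. Compound 3 `CCOc1ncnc2c1ncn2C[C@@H]1C[C@H](CO)c2ccccc21` carries an ethoxy group there and gives 24 ug/mL. Compound 3 stands level with compound 2, the two together at the highest numbers of the set, and the step of a 38-fold higher number from compound 1 to compound 3 (1.58 log units; beyond the scatter) is large. The step of no change at the digits printed from compound 2 to compound 3 (within the scatter) shows that hydroxy and ethoxy give numbers within the scatter of each other.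

Compound 4 `OC[C@H]1C[C@@H](Cn2cnc3c(NC4CC4)ncnc32)c2ccccc21` is not yet measured. Its difference from compound 3 is cyclopropylamino in place of ethoxy on an aromatic carbon. Among the compounds with values here, two measured steps bear on it: a 38-fold higher number from compound 1 to compound 3 (1.58 log units; beyond the scatter) and a 38-fold higher number from compound 1 to compound 2 (1.58 log units; beyond the scatter), both large, show that a small heteroatom-bearing group at this aromatic carbon gives a far higher number than 4-chlorophenyl, while no change at the digits printed from compound 2 to compound 3 (within the scatter) shows no change between two such groups. Cyclopropylamino is likewise a small heteroatom-bearing group, so in this assay the author expects a step of a 1.3-fold lower number from compound 3 to compound 4 (0.12 log units; within the scatter), close to compound 3 and within the scatter. Compound 4 is therefore estimated at 18 ug/mL, in the range 5 ug/mL to 60 ug/mL.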

Compound 4, half-maximal inhibitory concentration: 24 ug/mL
Compound 4: middle estimate off by 1.3-fold (0.12 log units), on the low side; the measured number falls inside the stated range.
By their numbers in this assay, from the lowest: compound 1; then compounds 2, 3 and 4 (each within the scatter of the next).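

In this assay, the step of no change at the digits printed from compound 3 to compound 4 (within the scatter) and the step of no change at the digits printed from compound 2 to compound 4 (within the scatter) extend the flat level at this aromatic carbon to a third group. Cyclopropylamino brings a nitrogen, a three-membered ring of carbon only and a hydrogen-bond donor that ethoxy does not have, yet none of these additions separates compound 4 from compound 2 or compound 3 in this read-out. The step of a 38-fold higher number from compound 1 to compound 4 (1.58 log units; beyond the scatter) leaves 4-chlorophenyl as the only group shown here that stands apart, so the large gap now separates compound 1 from compounds carrying oxygen-linked and nitrogen-linked groups alike, although no evidence at hand explains this level or that gap.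

The compounds shown leave open whether the lower number of compound 1 comes from the phenyl ring itself or from its chlorine, a question that an unsubstituted phenyl or a 4-methoxyphenyl group at this carbon would address. They also leave open whether a nitrogen-linked group can reach the number of compound 1 if it carries an aromatic ring of its own, as a benzylamino group does.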